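The compounds below may be only part of what the source reports. "The series", "measured", "known", "first", "only" and "open" are said of these compounds alone.

Compounds measured so far in a functional assay on CCRF-CEM cells (Homo sapiens) for antiproliferative activity, read by cell counting, with a stated time of 72 h; a lower number here means a stronger inhibitor, a higher number a weaker inhibitor:
compound 1, `C#C[C@@]1(O)[C@@H](CO)O[C@@H](n2cc(Cl)c3c(Cl)ccnc32)[C@@H]1O`, gives 1300 nM;
compound 2, `C#C[C@@]1(O)[C@@H](CO)O[C@@H](n2cc(Br)c3c(Cl)ccnc32)[C@@H]1O`, gives 560 nM;
compound 3, `C#C[C@@]1(O)[C@@H](CO)O[C@@H](n2ccc3c(Cl)ccnc32)[C@@H]1O`, gives 86000 nM.

Among these three numbers compound 1 stands second highest. Its nearest neighbour is compound 2, with a 2.3-fold lower number from compound 1 to compound 2 (0.37 log units; beyond the scatter), a modest step from the change of bromo in place of chloro on an aromatic carbon. Its furthest is compound 3, with a 66-fold higher number from compound 1 to compound 3 (1.82 log units; beyond the scatter), a large step from hydrogen in place of chloro on an aromatic carbon; the same removal from compound 2 gives a 150-fold higher number from compound 2 to compound 3 (2.19 log units; beyond the scatter).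

Compound 4, `C#C[C@@]1(O)[C@@H](CO)O[C@@H](n2cc(Cl)c3c(N)ccnc32)[C@@H]1O`, differs from compound 1 by amino in place of chloro on an aromatic carbon. Going by the values given here, none of the measured steps touches this position, so no direct precedent exists. Among the compounds with values here, the measured steps show only that this core responds strongly to what sits on it, and a group bringing a hydrogen-bond donor and acceptor in place of chloro is a larger change than any measured. The estimate is therefore uncertain in direction, with a modest improvement taken as the middle, expected as a 4.3-fold lower number from compound 1 to compound 4 (0.64 log units; beyond the scatter). Compound 4 is expected to give about 300 nM, within 40 nM to 2500 nM.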

Compound 4, half-maximal inhibitory concentration: 5400 nM
Compound 4: middle estimate off by 18-fold (1.26 log units), on the low side; the measured number lies above the stated range.
By their numbers in this assay, from the lowest: compound 2; then compound 1; then compound 4; then compound 3.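

Until compound 4, every step had changed the halogen on the five-membered side of the core, while the chloro opposite the ring nitrogen stayed fixed. In this assay, going by these compounds alone, the step of a 4.2-fold higher number from compound 1 to compound 4 (0.62 log units; beyond the scatter) is the first reading at this position, and it shows that amino in place of chloro weakens the compound modestly, far less than the large step of a 66-fold higher number from compound 1 to compound 3 (1.82 log units; beyond the scatter) seen on removing the other chloro. Nothing shown here gives a measured property that would account for this loss.

The compounds shown leave open how a methoxy, methylamino or dimethylamino group would fare at this position. They also leave open whether amino in place of chloro would cost as much with the bromo of compound 2 present.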